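The compounds below may be only part of what the source reports. "The series", "measured", "known", "first", "only" and "open" are said of these compounds alone.

Compound 2 `CC(C)C(NC(=O)NO)C(=O)NC1CCCC1` and compound 1 `CC(C)C(NC(=O)NO)C(=O)NC1CCCCC1` share one core and differ in a single place (cyclohexyl in place of cyclopentyl on an amide-type nitrogen). In a functional assay on WI-38 cells (Homo sapiens) for inhibition (on this read-out lower numbers stand for stronger inhibition and higher numbers for weaker inhibition), compound 2 reaches only a limit, > 100000 nM. In this assay compound 1 gives 58800 nM. The step is an at least 1.7-fold lower number from compound 2 to compound 1 (0.23 log units; that floor lies within the scatter), and its floor rests on (the limit of > 100000 nM in this assay, at which 1 of the 3 values shown sits). Compound 3 `CC(C)C(NC(=O)n1nnc2ccccc21)C(=O)NC1CCCC1` carries another core; the difference between the two cores is not broken down here. In this assay compound 3 likewise reaches only a limit, >= 100000 nM. Compound 4 `CC(C)C(NC(=O)n1nnc2ccccc21)C(=O)NC1CCCCC1` differs from compound 3 by the same change (cyclohexyl in place of cyclopentyl on an amide-type nitrogen), at a place described in the same words. The expected step is an at least 1.2-fold lower number from compound 3 to compound 4 (0.09 log units; that floor lies within the scatter), resting on an at least 1.7-fold lower number from compound 2 to compound 1 (0.23 log units; that floor lies within the scatter) and on the limit of compound 3 given by the limit of >= 100000 nM in this assay, at which 1 of the 3 values shown sits. Compound 4 is therefore estimated at about 80000 nM, with a likely range from 30000 nM to 300000 nM.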

Compound 4, half-maximal inhibitory concentration: >= 100000 nM
Compound 4 was reported as a limit; the forecaster's own chance of this, stated with the estimate: 60%; middle value at least 1.2-fold (0.09 log units) from the limit.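

For the compounds shown here, compound 3 and compound 4 both stand only as limits in this assay, so no step between them can be read. From the compounds shown here alone, whether cyclohexyl in place of cyclopentyl on an amide-type nitrogen shifts inhibition on this core remains open.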